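A few compounds are considered here, and "the series" means these few. Any claim that something is new, unique, unknown or untested is made for them only; others in the source may bear on it.

Series notes, urea chain bearing two fluorophenyl groups. In an ADME assay on isolated protein for inhibition of sodium-dependent dopamine transporter (Homo sapiens), tested at 10 uM (on this read-out lower numbers stand for less inhibition and higher numbers for more inhibition at the one concentration tested (going by the name of the read-out)), compound 1 `O=C(NCCCCC(c1ccc(F)cc1)c1ccc(F)cc1)Nc1ccc(Cl)cc1` gives 82%, while compound 2 `O=C(NCCCCC(c1ccc(F)cc1)c1ccc(F)cc1)Nc1ccc(Cl)cc1C(F)(F)F` gives 20%. For the measured compounds named here, compound 2 therefore stands as the lowest of the two numbers measured in this assay, with compound 1 the nearest neighbour; the step of a number 62 percentage points lower from compound 1 to compound 2 (beyond the scatter) is the only measured step and it lies well beyond the scatter.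

Compound 3 `Cc1cc(Cl)ccc1NC(=O)NCCCCC(c1ccc(F)cc1)c1ccc(F)cc1` is the next member: methyl in place of trifluoromethyl on an aromatic carbon. This undoes the trifluoromethyl that entered from compound 1 to compound 2, but puts a methyl in its place rather than hydrogen, on the aromatic carbon ortho to a large group and meta to a chloro group. Going by the values given here, the one step that bears on it, a number 62 percentage points lower from compound 1 to compound 2 (beyond the scatter), was large and downward. Since compound 3 keeps a substituent at that carbon, though a smaller one, the expected step is a number 30 percentage points higher from compound 2 to compound 3 (beyond the scatter), upward, landing between the two measured numbers. Compound 3 is estimated at 50% in this assay, within 20% to 80%.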

Compound 3, a percentage reported as inhibition, at one concentration (the size of the read-out at that concentration, not a potency): 58%
For compound 3 the middle estimate is 8 percentage points below the measured one, and the stated range covers the measured number.
By their numbers in this assay, from the lowest: compound 2; then compound 3; then compound 1.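

In this assay, methyl in place of hydrogen on this aromatic carbon gives a number 24 percentage points lower from compound 1 to compound 3 (beyond the scatter), so a substituent here need not cost as much as trifluoromethyl did. Methyl in place of trifluoromethyl at the same carbon gives a number 38 percentage points higher from compound 2 to compound 3 (beyond the scatter), which shows that the number depends on which group sits there and not only on whether the carbon is substituted. Nothing measured here bears on why these two groups differ.

The compounds shown leave open where a fluoro, methoxy or amine group on this carbon would fall relative to methyl and trifluoromethyl. As far as these compounds go, it also remains open whether the same order of hydrogen, methyl and trifluoromethyl would hold with a shorter chain on the urea or with the chloro group replaced by a bromo group.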